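The source may report more compounds than this note shows. Statements on the series, on what has been measured and on what is new or still open speak of the compounds shown alone.

Measured compounds:
- compound 1, `CCCS(=O)(=O)N1CCN(c2ccc(OCC3CCN(C(=O)OC(C)C)CC3)cn2)CC1`: 300 nM
- compound 2, `CCCS(=O)(=O)N1CCN(c2ccc(OCC3CCN(C(=O)NC(C)C)CC3)cn2)CC1`: 1000 nM
- compound 3, `CCCS(=O)(=O)N1CCN(c2ccc(OCC3CCN(C(=O)CC(C)C)CC3)cn2)CC1`: 1600 nM

All three share one core and differ only in the group on the carbonyl carbon. In a functional assay on CHO-K1 cells for agonist activity at Glucose-dependent insulinotropic receptor (Homo sapiens), read by a luciferase reporter, with a stated time of 5 h (a lower number here means that less compound is needed, a higher number that more compound is needed for the effect), compound 3 gives the highest of the three numbers; the step of a 1.6-fold higher number from compound 2 to compound 3 (0.20 log units; within the scatter) lies within the scatter, so the two cannot be told apart, while the step of a 5.3-fold higher number from compound 1 to compound 3 (0.73 log units; beyond the scatter) lies beyond it.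

Compound 4, `CCCS(=O)(=O)N1CCN(c2ccc(OCC3CCN(C(=O)NC(C)(C)C)CC3)cn2)CC1`, has not yet been measured. It differs from compound 3 in one place: (tert-butyl)amino in place of isobutyl on a carbonyl carbon. The closest guide is the step in which isobutyl replaced isopropylamino on the same carbonyl carbon, a 1.6-fold higher number from compound 2 to compound 3 (0.20 log units; within the scatter), a change too small to rise above the scatter. Going back from an isobutyl to a branched amino group, now one carbon larger, should then at most undo that small move, and nothing in these three compounds shows a large effect for going from isopropylamino to (tert-butyl)amino. The expected step for compound 4 is therefore a 1.6-fold lower number from compound 3 to compound 4 (0.20 log units; within the scatter), a small decrease at most, likely within the scatter. Compound 4 is estimated at 1000 nM, in a range from 400 nM to 2500 nM.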

Compound 4, half-maximal effective concentration: 800 nM
For compound 4 the middle estimate is 1.3-fold (0.10 log units) above the measured one; the range from low to high includes it.
By their numbers in this assay, from the lowest: compound 1; then compounds 4, 2 and 3 (each within the scatter of the next).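

In this assay, placing methyl for hydrogen on the saturated chain carbon bound to the amide-type nitrogen gives a 1.3-fold lower number from compound 2 to compound 4 (0.10 log units; within the scatter), so this added methyl produces no change that can be told apart from repeat-measurement noise. The exchange of isobutyl for (tert-butyl)amino on the carbonyl carbon gives a 2.0-fold lower number from compound 3 to compound 4 (0.30 log units; within the scatter), which also stays within the scatter, so compound 4 adds a third group at this position that cannot be separated from its nearest neighbours. The isopropoxy group of compound 1 still stands apart, since (tert-butyl)amino in its place gives a 2.7-fold higher number from compound 1 to compound 4 (0.43 log units; beyond the scatter), and compound 1 is now beyond the scatter from all three other compounds.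

Nothing shown here accounts for why isopropoxy differs from the other three groups. On these data alone, it remains open whether a tert-butoxy group on the same carbonyl carbon would give a number close to that of compound 1 or one close to that of compound 4, which would help show whether the oxygen or the size of the branched group matters more at this position.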